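The source may report more compounds than this note shows. Statements on the series, on what has been measured and on what is new or still open speak of the compounds shown alone.

Compound 2 `O=Cc1coc2ccc(OCc3cccc(Br)c3)cc2c1=O` gives 2200 nM in an assay on isolated protein for inhibition of Amine oxidase [flavin-containing] A (Homo sapiens), read by fluorescence, with a stated time of 20 min (a lower number here means a stronger inhibitor, a higher number a weaker inhibitor), and stands with the higher of the two numbers measured, whereas compound 1 `O=C(O)c1coc2ccc(OCc3cccc(Br)c3)cc2c1=O` gives 1040 nM. Within the data shown here, the only step measured, a 2.1-fold higher number from compound 1 to compound 2 (0.33 log units; beyond the scatter), exchanged hydrogen for hydroxy on the carbonyl carbon. Compound 3 `COC(=O)c1coc2ccc(OCc3cccc(Br)c3)cc2c1=O` carries methoxy in place of hydrogen on a carbonyl carbon, a change at the same carbonyl carbon. That single step was modest, so the author expects compound 3 to move by a 1.5-fold lower number from compound 2 to compound 3 (0.17 log units; within the scatter), tending back toward compound 1 but without a clear direction. The estimate for compound 3 is 1500 nM, with a range from 500 nM to 4500 nM.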

Compound 3, half-maximal inhibitory concentration: 6460 nM
For compound 3 the middle estimate is 4.3-fold (0.63 log units) below the measured one, and the stated range ends below it.
By their numbers in this assay, from the lowest: compound 1; then compound 2; then compound 3.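

In this assay, the change at this carbonyl carbon is not a small one: methoxy in place of hydrogen gives a 2.9-fold higher number from compound 2 to compound 3 (0.47 log units; beyond the scatter), and the ester also loses ground against the acid, with a 6.2-fold higher number from compound 1 to compound 3 (0.79 log units; beyond the scatter). Of hydroxy, hydrogen and methoxy on this carbon, methoxy gives the weakest inhibitor, and both steps lie beyond the scatter. Nothing at hand accounts for this order. The compounds shown leave open how an amide formed with an amine, or an ester with a longer chain, would read at this carbonyl carbon.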